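A Larger Group on the Ring Nitrogen of Compound 1

A few compounds are considered here, and "the series" means these few. Any claim that something is new, unique, unknown or untested is made for them only; others in the source may bear on it.

Compound 1 `Cn1cccc1-c1cc(-c2ccc(Br)cc2)[nH]c(=O)c1C#N` is one of two compounds that have been tested in a functional assay on EKVX cells (Homo sapiens) for cytotoxicity, read by sulforhodamine B assay, with a stated time of 48 h (a higher number here means a weaker inhibitor of growth, a lower number a stronger inhibitor of growth), and in this assay compound 1 gives 27500 nM. Compound 2 `COc1ccc(-c2cc(-c3cccs3)[nH]c(=O)c2C#N)cc1` belongs to the same set. In this assay compound 2 reaches only a limit, > 100000 nM, and so returns no number. Among the compounds with values here, compound 1 thus stands as the only numerical value on record, the other entry being (the limit of > 100000 nM in this assay, at which 1 of the 2 values shown sits). Within the data shown here, no pair of measured compounds differs in a single place, so the size of any single step has not yet been seen in this assay.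

Compound 3 `Cn1cccc1-c1cc(-c2ccc(Br)cc2)n(C(=S)Nc2ccc(F)cc2)c(=O)c1C#N` differs from compound 1 by a group of 10 heavy atoms (7 carbon, 1 nitrogen, 1 fluorine, 1 sulfur; one six-membered aromatic ring of carbon only) in place of a hydrogen atom, on an aromatic nitrogen. Among the measured compounds shown here, with no measured step to lean on, the account expects the step of a 1.5-fold lower number from compound 1 to compound 3 (0.18 log units; within the scatter) to be small, within the scatter or only slightly beyond it, tending toward stronger inhibition of growth. For compound 3 the expected value is 18000 nM, with a range from 5000 nM to 70000 nM.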

Compound 3, concentration for 50% growth inhibition: 10 nM
Beside the measured number, compound 3's estimate is 1800-fold (3.26 log units) above it; the whole stated range lies above it.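

In this assay, the aromatic nitrogen of compound 1 proves to be a position that accepts a large group in place of its hydrogen atom and responds strongly to the change: the group of 10 heavy atoms, with its one six-membered aromatic ring of carbon only, gives a 2800-fold lower number from compound 1 to compound 3 (3.44 log units; beyond the scatter), toward stronger inhibition of growth. Within the data shown here, until this result no single change had been seen in the set, so neither the importance of this nitrogen nor the size a single step can reach was known, and this first step lies well beyond the scatter. Nothing shown speaks to the cause of a step of this size.

The group enters as a whole, so the compounds shown do not separate the contributions of its sulfur, its nitrogen and its fluorine, nor show what a simple methyl or acetyl group would do on the same ring nitrogen. Also open, on these data alone, is whether a carbonyl in place of the sulfur, or a chlorine in place of the fluorine, would keep the number of compound 3.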